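The source may report more compounds than this note shows. Statements on the series, on what has been measured and on what is new or still open speak of the compounds shown alone.

Working notes on the series, all read in a functional assay on HeLa cells (Homo sapiens) for inhibition, read by MTT assay, with a stated time of 72 h; a higher number here means a weaker inhibitor, a lower number a stronger inhibitor. Compound 1 `Nc1nc2cc(-c3nn(CCCC(=O)NO)c4ncnc(N)c34)ccc2o1` reads > 150000 nM, and this is a limit of the assay. Compound 2 `Nc1nc2cc(-c3nn(CCCCCC(=O)NO)c4ncnc(N)c34)ccc2o1` gives 15400 nM, and compound 3 `CNC(=O)CCCCCCCn1nc(-c2ccc3oc(N)nc3c2)c2c(N)ncnc21` gives 12900 nM. Going by the values given here, compound 3 therefore stands level with its only numerical neighbour: a 1.2-fold lower number from compound 2 to compound 3 (0.08 log units; within the scatter), within the scatter.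

Compound 4 `Nc1nc2cc(-c3nn(CCCCCCC(=O)NO)c4ncnc(N)c34)ccc2o1` differs from compound 3 by hydroxycarbamoyl in place of (methylcarbamoyl)methyl on a saturated chain carbon, six bonds along the chain from an aromatic nitrogen: hydroxycarbamoyl in place of (methylcarbamoyl)methyl, on a saturated chain carbon, six bonds along the chain from an aromatic nitrogen.

Among the compounds with values here, two measured steps bear on this change. Within the data shown here, with hydroxycarbamoyl kept at the chain end, the closest precedent is an at least 9.7-fold lower number from compound 1 to compound 2 (0.98 log units; beyond the scatter), which lengthens the chain and is beyond the scatter. The other, a 1.2-fold lower number from compound 2 to compound 3 (0.08 log units; within the scatter), changes chain and end group together, so it cannot separate the two.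

A modest move to a lower number in this assay is therefore expected, with the expected step being a 2.6-fold lower number from compound 3 to compound 4 (0.41 log units; beyond the scatter). For compound 4 the estimate is 5000 nM, with an expected range of 1200 nM to 14000 nM.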

Compound 4, half-maximal inhibitory concentration: 6410 nM
Compound 4: the middle estimate sits 1.3-fold (0.11 log units) below what was measured; low and high end bracket the measured number.
By their numbers in this assay, from the lowest: compounds 4, 3 and 2 (each within the scatter of the next, the first and the last beyond it). At a limit, above all of these: compound 1.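

In this assay, hydroxycarbamoyl in place of (methylcarbamoyl)methyl at this position gives a 2.0-fold lower number from compound 3 to compound 4 (0.30 log units; within the scatter), so this change, which also alters the chain, does not set the two end groups apart. Going by these compounds alone, with hydroxycarbamoyl kept at the chain end, the new steps are a 2.4-fold lower number from compound 2 to compound 4 (0.38 log units; beyond the scatter) and an at least 23-fold lower number from compound 1 to compound 4 (1.36 log units; beyond the scatter); across compounds 1, 2 and 4, the lower numbers go with the longer chains, and no compound with this end group goes against that. The second of these steps rests on compound 1, whose value is a limit and not a number: the limit of > 150000 nM in this assay, at which 1 of the 4 values shown sits.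

No pair shown compares the two end groups on a chain of equal length, so the contribution of the end group alone stays unresolved. Also open, going by these compounds, are how a carboxylic acid at the chain end would read and whether a longer chain ending in hydroxycarbamoyl would extend the trend.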